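The source may hold more compounds than are shown below. What is called first, only, known or untested is meant among the compounds shown, and "the series" means these compounds.

Of the compounds shown here, two with a shared core have been measured in a functional assay on HepG2 cells (Homo sapiens) for antiproliferative activity, read by MTT assay, with a stated time of 24 h; on this read-out lower numbers stand for stronger inhibition and higher numbers for weaker inhibition. Compound 1 `O=c1[nH]cc(S(=O)(=O)Nc2ccccc2-c2cn(-c3ccc(Cl)cc3)nn2)c(=O)[nH]1` is the more active of the pair: in this assay compound 1 gives 1840 nM. Compound 2 `Cc1ccccc1-n1cc(-c2ccc(NS(=O)(=O)c3c[nH]c(=O)[nH]c3=O)cc2)nn1` stands at the highest number of the two: in this assay compound 2 gives 14500 nM, and the gap to compound 1 is beyond the scatter of repeated measurements. No single-point change links compound 1 and compound 2, so the two numbers only show that compound 2 is the weaker of the measured pair.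

Compound 3 `O=c1[nH]cc(S(=O)(=O)Nc2ccc(-c3cn(-c4ccccc4Cl)nn3)cc2)c(=O)[nH]1` has not yet been measured. It differs from compound 2 in one place: chloro in place of methyl on an aromatic carbon. The exchange sits on an aromatic carbon of a six-membered aromatic ring of carbon only, ortho to a large group, and read one bond further out it turns 2-methylphenyl into 2-chlorophenyl. Within the data shown here, nothing among the measured compounds isolates this exchange, so the expectation rests on the change itself. The step from compound 2 to compound 3 is expected to be small, if anything toward a lower number, with a 1.6-fold lower number from compound 2 to compound 3 (0.21 log units; within the scatter). Compound 3 is therefore estimated at 9000 nM, within a range of 3000 nM to 30000 nM.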

Compound 3, half-maximal inhibitory concentration: 2230 nM
Compound 3: middle estimate off by 4.0-fold (0.61 log units), on the high side, outside the stated range (below it).
By their numbers in this assay, from the lowest: compounds 1 and 3 (each within the scatter of the next); then compound 2.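

In this assay, putting chloro in place of methyl on an aromatic carbon, ortho to a large group, gives a 6.5-fold lower number from compound 2 to compound 3 (0.81 log units; beyond the scatter), a step beyond the scatter of repeated measurements. Among these compounds, this is the first single-place comparison, and it shows that the read-out is sensitive to what this position carries, even though methyl and chloro each count as one heavy atom, with no ring, no hydrogen-bond donor or acceptor and no net charge. Nothing available explains why the exchange moves the number this far.

The compounds shown rest on one exchange at one position, so they leave open whether chloro is specifically favoured there or whether other groups, such as fluoro, methoxy or an amine, would give a similar or a larger step. They also leave open whether the same exchange from 2-methylphenyl to 2-chlorophenyl would give a step of this size on a different core, or with the group elsewhere on the ring.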